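The source may hold more compounds than are shown below. What is called first, only, known or untested is meant among the compounds shown, and "the series" means these compounds.

Measured so far:
- compound 1, `CNC(=O)/C=C/c1ccncc1-c1ccc2ccccc2c1`: 12.4 nM
- compound 2, `CNC(=O)COc1ccncc1-c1ccc2ccccc2c1`: "not determined" (no result reported)

The shared core is the same in both. In an assay on a protein complex for inhibition of CDK8/Cyclin C (Homo sapiens), with a stated time of 1 h (a higher number here means a weaker inhibitor, a lower number a stronger inhibitor), compound 1 gives 12.4 nM. Compound 2 carries the (methylcarbamoyl)methoxy group in place of the side chain of compound 1, and for compound 2 no single number is reported in this assay, so there is no measured value to stand on.

Compound 3, `NNC(=O)CCc1ccncc1-c1ccc2ccccc2c1`, is the next compound and has not been measured. It differs from compound 2 in one place: 2-(aminocarbamoyl)ethyl in place of (methylcarbamoyl)methoxy on an aromatic carbon. For the measured compounds named here, since compound 2 has no result, no step from compound 2 to compound 3 in this assay can be given a size or a direction from the data; the expectation for compound 3 therefore rests only on the shared core and on compound 1 as the single compound with a value.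

For compound 3 in this assay the estimated half-maximal inhibitory concentration is 150 nM, with a range from 20 nM to 1500 nM.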

Compound 3, half-maximal inhibitory concentration: 7.7 nM
The estimate for compound 3 lay 19-fold (1.29 log units) above the measured number; the whole stated range lies above it.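

In this assay, placing 2-(aminocarbamoyl)ethyl in place of 2-(methylcarbamoyl)ethenyl on this aromatic carbon gives a 1.6-fold lower number from compound 1 to compound 3 (0.21 log units; within the scatter), so the two side chains cannot be told apart here. For the compounds shown here, this is the first sign that the position, ortho to a large group and opposite the ring nitrogen, accepts more than one side chain with a value of this order: compound 3 has an ethyl link where compound 1 has an ethenyl link, and its amide carries an amino group where compound 1 has a methyl, yet the result stays within the scatter. Both differences sit in this single step, so their separate contributions cannot be read, and nothing available bears on why the two compounds stay so close.

The steps involving compound 2 cannot be read, which leaves open how a (methylcarbamoyl)methoxy group at this position compares with either side chain. Also open, on these data alone, is what a carboxylic acid, a simple amine or a longer chain ending in the same aminocarbamoyl group would give at this position in this assay.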